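The compounds below may be only part of what the source reports. "The series", "measured", "known", "first", "only" and "open" are said of these compounds alone.

Compound 1 `CC(C)=NNC(=O)c1ccc2[nH]c(C)nc2c1` gives in a functional assay on A549 cells (Homo sapiens) for cytotoxicity, read by resazurin assay, with a stated time of 72 h (a higher number here means a weaker inhibitor, a lower number a stronger inhibitor), a value reported only as a limit of the assay, > 100000 nM. Compound 2 `Cc1nc2cc(C(=O)N/N=C\c3ccco3)c([N+](=O)[O-])cc2[nH]1` likewise gives in this assay only a limit, > 100000 nM.

Going by the values given here, compound 2 therefore has no exact number; its result is a limit, and the one other value shown is a limit too, as both sit at the limit of > 100000 nM in this assay, at which 2 of the 2 values shown sit. Compound 3 `Cc1nc2cc(C(=O)N/N=C\c3c[nH]c4ccccc34)c([N+](=O)[O-])cc2[nH]1` is the next compound to be measured in this assay. It differs from compound 2 in one place: 1H-indol-3-yl in place of furan-2-yl on a carbon with a double bond to nitrogen. Among the compounds with values here, no step between two measured compounds is available here, so the effect of this change cannot be read from the data. With both measured values resting at a limit, the step from compound 2 to compound 3 is expected to be none beyond the usual scatter, a step that the limit leaves unreadable from compound 2 to compound 3. For compound 3 the expected result in this assay is 150000 nM, with a range from 30000 nM to 1000000 nM, and most likely again reported only as a limit.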

Compound 3, half-maximal inhibitory concentration: > 100000 nM
Compound 3 was reported as a limit; the forecaster's own chance of this, stated with the estimate: 70%; the middle value does not contradict the limit.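

Going by these compounds alone, compound 2 and compound 3 are both reported in this assay only as limits, so no step between them can be read, and the change from furan-2-yl to 1H-indol-3-yl has no size that can be stated. All three results share one limit: the limit of > 100000 nM in this assay, at which 3 of the 3 values shown sit.

The compounds shown leave open which structural changes, if any, would give an exact value in this assay.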